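The source may hold more compounds than are shown below. What is called first, only, known or untested is meant among the compounds shown, and "the series" means these compounds.

In a functional assay on MCF7 cells (Homo sapiens) for inhibition, read by MTT assay, with a stated time of 72 h (on this read-out higher numbers stand for weaker inhibition and lower numbers for stronger inhibition), compound 1 `C/C1=C\CC[C@@]2(C)O[C@@H]2[C@H]2OC(=O)[C@@H](CN3CCCCC3)[C@@H]2C[C@H]1O` gives 16000 nM and compound 2 `C[C@]12O[C@@H]1CC[C@@]1(C)O[C@@H]1[C@H]1OC(=O)[C@@H](CN3CCN(c4ccccc4)CC3)[C@@H]1C[C@H]2O` gives 59000 nM as the higher of the two numbers, a gap beyond the usual scatter, so compound 2 is the weaker inhibitor of the pair. Compound 3 `C[C@]12O[C@@H]1CC[C@@]1(C)O[C@@H]1[C@H]1OC(=O)[C@@H](CN3CCN(c4ccc(Cl)cc4)CC3)[C@@H]1C[C@H]2O` carries chloro in place of hydrogen on an aromatic carbon, para to a large group, a change counted as chloro in place of hydrogen on an aromatic carbon and turning phenyl into 4-chlorophenyl. Going by the values given here, no measured pair shows this change, so in this assay only a small step toward a lower number is expected, possibly none beyond the scatter. The estimated change a 1.5-fold lower number from compound 2 to compound 3 (0.17 log units; within the scatter) is modest. For compound 3 the expected value is 40000 nM within a range of 15000 nM to 90000 nM as an estimate.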

Compound 3, half-maximal inhibitory concentration: 29000 nM
The estimate for compound 3 lay 1.4-fold (0.14 log units) above the measured number, within the range that was stated.
By their numbers in this assay, from the lowest: compounds 1 and 3 (each within the scatter of the next); then compound 2.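

In this assay, chloro in place of hydrogen on the aromatic ring, para to a large group, gives a 2.0-fold lower number from compound 2 to compound 3 (0.31 log units; beyond the scatter) and so moves the number toward stronger inhibition. Going by these compounds alone, this is the first measured sign that a single added atom on this phenyl group can shift the read-out, although only modestly. Nothing shown accounts for the size or direction of this step.

From the compounds shown here alone, whether fluoro, methoxy or nitrile in the same place would give a similar step remains open. So does whether chloro elsewhere on this ring would.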